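This account rests on a few compounds, and the source may have more. Where it says the series, first, only, none or still open, it means among the compounds named here.

Two measured compounds share the same macrocyclic core. Compound 1 `CO[C@H]1C[C@H](C)CC2=C(N3CCC3)C(=O)C=C(NC(=O)/C(C)=C/C=C\[C@H](OC)[C@@H](OC(N)=O)/C(C)=C/[C@H](C)C1=O)C2=O` in a functional assay on SK-BR-3 cells (Homo sapiens) for cytotoxicity, read by CellTiter-Glo, with a stated time of 72 h (a lower number here means a stronger inhibitor, a higher number a weaker inhibitor), gives 260 nM. Compound 2 `CO[C@H]1C[C@H](C)CC2=C(NCCN(C)C)C(=O)C=C(NC(=O)/C(C)=C/C=C\[C@H](OC)[C@@H](OC(N)=O)/C(C)=C/[C@H](C)/C1=N\OCC(=O)O)C2=O` in this assay gives 2700 nM, the higher of the two numbers; the gap between compound 2 and compound 1 lies well beyond the usual scatter, so compound 2 is the weaker of the pair here.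

Compound 3 `CO[C@H]1C[C@H](C)CC2=C(NCCN(C)C)C(=O)C=C(NC(=O)/C(C)=C/C=C\[C@H](OC)[C@@H](OC(N)=O)/C(C)=C/[C@H](C)/C1=N\OCc1ccccc1)C2=O` has not yet been measured. It differs from compound 2 in one place: phenyl in place of carboxy on a saturated chain carbon bound to an oxygen — carboxymethoxy becomes benzyloxy on the oxime. Within the data shown here, no measured step between two compounds isolates this change, so nothing comparable is on record.

The step from compound 2 to compound 3 is expected to lower the number moderately, a 3.0-fold lower number from compound 2 to compound 3 (0.48 log units; beyond the scatter), given that compound 2 sits at 2700 nM with room to move toward compound 1. Compound 3 is therefore estimated at 900 nM in this assay, within a range from 250 nM to 3000 nM.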

Compound 3, half-maximal inhibitory concentration: 480 nM
Beside the measured number, compound 3's estimate is 1.9-fold (0.27 log units) above it; low and high end bracket the measured number.
By their numbers in this assay, from the lowest: compounds 1 and 3 (each within the scatter of the next); then compound 2.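

Among these compounds, on the oxime of compound 2, carboxymethoxy becomes benzyloxy, and this gives the first step on record in this assay that isolates a single change: a 5.6-fold lower number from compound 2 to compound 3 (0.75 log units; beyond the scatter). The result shows that the number in this assay responds to what the oxime carries, with a change beyond the scatter when phenyl replaces carboxy on a saturated chain carbon bound to an oxygen. Nothing measured here bears on why the number falls.

As far as these compounds go, whether the step comes from gaining the phenyl ring or from losing the carboxy group stays open: a methyl ether on the oxime would help to separate the two. Also open, from the compounds shown here alone, is how the number would respond to a longer chain such as phenethyl, or to a benzyl group carrying a fluorine or a methoxy group on its ring.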